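Pyridinyl for chlorophenyl on the pyrazole nitrogen

This account rests on a few compounds, and the source may have more. Where it says the series, first, only, none or still open, it means among the compounds named here.

Compound 1 `O=C([C@@H]1C[C@H](N2CCN(c3ccccn3)CC2)CN1)N1CCSC1` gives 62.7% in a functional assay on the whole organism (plasma, strain Wistar) for inhibition, with Rattus norvegicus as the target, read by fluorescence, with a stated time of 0.5 h, at a dose of 3 umol/kg by the oral route (on this read-out higher numbers stand for more inhibition at the one dose given (going by the name of the read-out) and lower numbers for less inhibition), while compound 2 `O=C([C@@H]1C[C@H](N2CCN(c3nnnn3C3CCCCC3)CC2)CN1)N1CCSC1` gives 25.6% in this assay. Compound 3 `Cc1cc(N2CCN([C@@H]3CN[C@H](C(=O)N4CCSC4)C3)CC2)n(-c2ccc(Cl)cc2)n1` was tested in this assay but its result is given only as "not determined" (no result reported), with no single number reported, so it stands nowhere on the numbers shown. Compound 4 `Cc1cc(N2CCN([C@@H]3CN[C@H](C(=O)N4CCSC4)C3)CC2)n(-c2cccnc2)n1` differs from compound 3 by one change: pyridin-3-yl in place of 4-chlorophenyl on an aromatic nitrogen. No step between measured compounds is shown, and compound 3 has no value to step from, so the direction of this change cannot be read from the data. The spread between compound 1 and compound 2 in this assay suggests a moderate read-out is plausible. Compound 4 is expected to give about 40% in this assay, within a range from 15% to 65%.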

Compound 4, a percentage reported as inhibition, in the whole organism at one dose (the size of the read-out at that dose, not a potency): 66.9%
Beside the measured number, compound 4's estimate is 26.9 percentage points below it; the whole stated range lies below it.
By their numbers in this assay, from the lowest: compound 2; then compounds 1 and 4 (each within the scatter of the next).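

Among the compounds shown here, compound 3 has no number in this assay and so no step from it to compound 4 can be read. The compounds shown leave open what pyridin-3-yl in place of 4-chlorophenyl does to inhibition. Nothing given here bears on the result.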